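Methyl placement on the shared core of the amide series

The source may hold more compounds than are shown below. What is called first, only, known or untested is meant among the compounds shown, and "the series" means these compounds.

The series shares the core of compound 2 `Cc1ccc2nc(-c3cccc(NC(=O)CCc4ccccc4)c3)[nH]c2c1`, an aryl amide on a fused aromatic system. In an assay on cells for inhibition of matrix metalloproteinase-9 (Homo sapiens), read by fluorescence, with stated times of 15 min and 4 h (on this read-out higher numbers stand for weaker inhibition and lower numbers for stronger inhibition), compound 2 gives 26600 nM. Compound 3 `O=C(CCc1ccccc1)Nc1cccc(-c2nc3ccccc3[nH]2)c1` lacks the methyl of compound 2; in this assay compound 3 gives 68000 nM, the highest of the two numbers measured, and the step of a 2.6-fold higher number from compound 2 to compound 3 (0.41 log units; beyond the scatter) sets it beyond the scatter from its nearest neighbour. Compound 1 `Cc1ccc2nc(-c3cccc(NC(=O)CN(C)Cc4ccccn4)c3)[nH]c2c1` carries a methyl((pyridin-2-yl)methyl)amino group on the chain carbon bound to the carbonyl carbon; in this assay compound 1 reaches only > 100000 nM, which is a limit of the assay and not a number (the limit of > 100000 nM in this assay, at which 1 of the 3 values shown sits). The step of an at least 3.7-fold lower number from compound 1 to compound 2 (0.57 log units; beyond the scatter) shows the benzyl variant with an at least modestly lower number.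

Compound 4 `Cc1cccc2nc(-c3cccc(NC(=O)CCc4ccccc4)c3)[nH]c12` is compound 3 with methyl in place of hydrogen on an aromatic carbon. Among the compounds with values here, the one measured step that bears on this change is a 2.6-fold higher number from compound 2 to compound 3 (0.41 log units; beyond the scatter), the loss of a methyl from the fused system, though the methyl of compound 2 sits at a different place on the ring system than the one entering here; reversing that step is the only guide available. A modestly lower number is therefore expected in this assay, a 1.7-fold lower number from compound 3 to compound 4 (0.23 log units; within the scatter). Compound 4 is estimated at 40000 nM, with a range from 15000 nM to 120000 nM.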

Compound 4, half-maximal inhibitory concentration: 60000 nM
Estimate against measurement, compound 4: 1.5-fold (0.18 log units) below, and the stated range covers the measured number.
By their numbers in this assay, from the lowest: compound 2; then compounds 4 and 3 (each within the scatter of the next). At a limit, above all of these: compound 1.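

In this assay, methyl in place of hydrogen on this aromatic carbon, ortho to a fused ring and meta to a fused ring, gives a 1.1-fold lower number from compound 3 to compound 4 (0.05 log units; within the scatter), so the change at this position cannot be told from the scatter. The earlier compounds shown here held only the methyl of compound 2, which sits at a different place on the shared core and for which a 2.6-fold higher number from compound 2 to compound 3 (0.41 log units; beyond the scatter) lies beyond the scatter; on these two places alone, the entry of a methyl does not read the same at each, and no wider rule on the core follows from them. No measurement shown bears on why the two places read differently.

Still open, on these data alone, is whether another group on this same aromatic carbon, such as a methoxy group, a chlorine atom, an amine or a carboxylic acid, would give a step beyond the scatter in this assay. Also open, as far as these compounds go, is whether a methyl at this place would read the same on a compound carrying the methyl((pyridin-2-yl)methyl)amino group of compound 1 or a longer chain in the amide.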